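Trimming the side chain of compound 2

The compounds below may be only part of what the source reports. "The series", "measured", "known", "first", "only" and "open" are said of these compounds alone.

Within the data shown here, in a functional assay on MDA-MB-231 cells (Homo sapiens) for cytotoxicity, read by MTT assay, with a stated time of 72 h (a lower number here means a stronger inhibitor, a higher number a weaker inhibitor), compound 2 `CN1CCN(CCCCCCn2c3c(c4ccccc42)C(=O)c2c[n+]([O-])c4ccccc4c2C3=O)CC1` gives 2400 nM and stands highest of the two numbers so far, while compound 1 `CN(C)CCCCCn1c2c(c3ccccc31)C(=O)c1c[n+]([O-])c3ccccc3c1C2=O` gives 240 nM on the same core. Compound 3 `CN1CCN(CCCCCn2c3c(c4ccccc42)C(=O)c2c[n+]([O-])c4ccccc4c2C3=O)CC1` differs from compound 2 by 4-methylpiperazin-1-yl in place of (4-methylpiperazin-1-yl)methyl on a saturated chain carbon, five bonds along the chain from an aromatic nitrogen on a saturated chain carbon, five bonds along the chain from an aromatic nitrogen. Among the measured compounds shown here, the one measured step is a 10-fold higher number from compound 1 to compound 2 (1.00 log units; beyond the scatter) and it also brought in the 4-methylpiperazin-1-yl group that compound 3 keeps, so only part of it should be undone. In this assay the expected step is a 3.0-fold lower number from compound 2 to compound 3 (0.48 log units; beyond the scatter) and it should be smaller than the measured one. Compound 3 is estimated at 800 nM with 250 nM to 2500 nM as the expected range.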

Compound 3, half-maximal inhibitory concentration: 2270 nM
For compound 3 the middle estimate is 2.8-fold (0.45 log units) below the measured one; measured number inside the range.
By their numbers in this assay, from the lowest: compound 1; then compounds 3 and 2 (each within the scatter of the next).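

In this assay, going from the longer to the shorter chain stays within the usual scatter, with a 1.1-fold lower number from compound 2 to compound 3 (0.02 log units; within the scatter) as the step. With the chain held the same, a 9.5-fold higher number from compound 1 to compound 3 (0.98 log units; beyond the scatter) is the step for 4-methylpiperazin-1-yl in place of dimethylamino alone, so the gap seen earlier goes with that amine swap and not with chain length. Nothing measured here explains why the swap has this effect.

Still open, on these data alone, is how a morpholine ring or a diethylamino group would read at this place on the chain. As far as these compounds go, whether dimethylamino on a longer chain would keep the number of compound 1 also remains open.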